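The source may report more compounds than this note shows. Statements on the series, on what has been measured and on what is new or still open speak of the compounds shown alone.

Within the data shown here, in an ADME assay on MDBK cells (Bos taurus) for cytotoxicity (a lower number here means that less compound is tolerated, a higher number that more compound is tolerated), compound 2 (`Clc1ccc(Cn2ccc3nc(-c4ccccc4)nc-3c2)cc1Cl`) gives 71000 nM as the only actual number so far. Compound 1 (`Clc1ccccc1Cn1ccc2nc(-c3ccccc3)nc-2c1`) gives > 100000 nM as a limit of the assay and not a number. Among the measured compounds shown here, the single measured step is an at least 1.4-fold lower number from compound 1 to compound 2 (0.14 log units; that floor lies within the scatter) and sets no firm size for a change of group at this place. Compound 3 (`c1ccc(-c2nc3ccn(CC4CCCCC4)cc-3n2)cc1`) carries the change cyclohexyl in place of 3,4-dichlorophenyl on a saturated chain carbon bound to an aromatic nitrogen on the shared core, with cyclohexyl in place of 3,4-dichlorophenyl on a saturated chain carbon bound to an aromatic nitrogen. For the measured compounds named here, with only that one step from compound 1 to compound 2 as a guide, no shift beyond the scatter is expected in this assay for this change. The expected step is a 1.2-fold lower number from compound 2 to compound 3 (0.07 log units; within the scatter) and so stays within the scatter. Compound 3 is estimated at 60000 nM (range 20000 nM to 130000 nM).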

Compound 3, half-maximal cytotoxic concentration: > 100000 nM
Compound 3 ended at the assay's limit (the forecaster's own chance of this, stated with the estimate: 30%); middle value at least 1.6-fold (0.22 log units) from the limit.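

In this assay, the position on a saturated chain carbon bound to an aromatic nitrogen now carries a non-aromatic ring of carbon only, and the change to cyclohexyl gives an at least 1.4-fold higher number from compound 2 to compound 3 (0.14 log units; that floor lies within the scatter). Compound 3 gives > 100000 nM, which is a limit of the assay and not a number. The step from compound 1 to compound 3 cannot be read because both compounds sit at the same limit: the limit of > 100000 nM in this assay, at which 2 of the 3 values shown sit.

Among these compounds, with compound 2 as the only actual number, the true size of any change at this place stays open, and the series gives no ranking of 2-chlorophenyl against cyclohexyl. Also open, going by these compounds, is whether an amine, a carboxylic acid or a longer chain at this place would give a number within the range of this assay.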